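Inverting two ring stereocentres of compound 2

A few compounds are considered here, and "the series" means these few. Any claim that something is new, unique, unknown or untested is made for them only; others in the source may bear on it.

compound 1, `O=C(N[C@H](CO)C(=O)O)[C@@H]1C[C@H](O)CN1`: in an ADME assay (Mus musculus, strain C57BL/6) for metabolic stability, read by HPLC, with a stated time of 12 h (a lower number here means that the compound disappears faster, a higher number that the compound lasts longer), compound 1 gives > 12 h, a limit of the assay.
compound 2, `O=C(O)[C@H](CO)NC(=O)[C@H]1C[C@H](O)CN1`: in this assay compound 2 gives > 12 h, also a limit of the assay.

Compound 2 therefore stands at the limit, which the limit of > 12 h in this assay, at which 2 of the 2 values shown sit, shows both measured compounds reach. The step that the two limits leave unreadable from compound 1 to compound 2 is unreadable, so the two limits carry no size. Compound 3, `O=C(O)[C@H](CO)NC(=O)[C@@H]1C[C@@H](O)CN1`, differs from compound 2 in that (the two compounds have the same atoms and bonds and differ only in configuration as drawn: 2 of 3 stereo elements differ; a stereocentre at a saturated ring carbon is drawn R in compound 2 and S in compound 3; a stereocentre at a saturated ring carbon is drawn S in compound 2 and R in compound 3). Among the measured compounds shown here, no measured step shows configuration moving this readout off the limit, so compound 3 is expected to give 12 h in this assay, within 6 h to 24 h, an estimated step of a number no higher from compound 2 to compound 3 (the limit leaves the size open) no larger than the scatter.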

Compound 3, half-life in the Mus musculus assay: 0.88 h
Compound 3: middle estimate off by 14-fold (1.13 log units), on the high side, and the stated range ends above it.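

In the Mus musculus assay, configuration alone now moves the read-out off the limit, with an at least 13-fold lower number from compound 2 to compound 3 (1.13 log units; beyond the scatter) and an at least 13-fold lower number from compound 1 to compound 3 (1.13 log units; beyond the scatter): the fact that compounds 2 and 3 differ only in the configuration as drawn
In a physicochemical assay for metabolic stability, read by HPLC, with a stated time of 12 h, at pH 1.2 (on this read-out lower numbers stand for a shorter-lived compound and higher numbers for a longer-lived compound), compound 2 gives > 12 h, a limit of the assay.
In the physicochemical assay compound 3 gives > 12 h, also a limit of the assay.

Among the compounds shown here, the steps between two limits cannot be read, and whether inverting only one of the ring stereocentres would be enough to lower the half-life in the Mus musculus assay stays open. Going by these compounds, how compound 3 would behave with an ester in place of the carboxylic acid also stays open.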